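Terminal amide nitrogen change from compound 2 to compound 3

The compounds below may be only part of what the source reports. "The series", "measured", "known", "first", "only" and "open" are said of these compounds alone.

Measured compounds:
compound 1 `CC[C@H](C)[C@H](NC(=O)c1cccc(Cn2ccnc2)c1)C(=O)Nc1nccs1` – 17%
compound 2 `CC[C@H](C)[C@H](NC(=O)c1cccc(Cn2ccnc2)c1)C(=O)NNC(=O)OC(C)(C)C` – "not determined" (no result reported)

In an assay on HEK293 cells for displacement of a labelled ligand from Type-2 angiotensin II receptor (Homo sapiens), tested at 10 uM (on this read-out lower numbers stand for a weaker effect and higher numbers for a stronger effect at the one concentration tested), compound 1 gives 17%, a low read-out at the one concentration tested. For compound 2 the same read-out is "not determined" (no result reported), so compound 2 stands without a single number in this assay and its place in the series is open; the only measured point of reference is compound 1, which sits low. Compound 3 `CC[C@H](C)[C@H](NC(=O)c1cccc(Cn2ccnc2)c1)C(=O)NO` differs from compound 2 in one place: hydroxy in place of (tert-butoxycarbonyl)amino on an amide-type nitrogen. For the measured compounds named here, no step between measured compounds is available to gauge a change of this kind. The expected step for compound 3 in this assay is small, with no direction that would clearly exceed the scatter, given that the one measured relative, compound 1, gives 17%. Compound 3 is expected to give about 15% in this assay, estimated between 0% and 40%.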

Compound 3, a percentage reported as inhibition, at one concentration (the size of the read-out at that concentration, not a potency): 4%
The estimate for compound 3 lay 11 percentage points above the measured number; the measured number falls inside the stated range.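

In this assay, hydroxy in place of 1,3-thiazol-2-yl on the amide-type nitrogen gives a number 13 percentage points lower from compound 1 to compound 3 (beyond the scatter), so the read-out at this position responds to the group placed there, although both measured compounds remain low. The change from (tert-butoxycarbonyl)amino to hydroxy cannot be read, as compound 2 has no number. Nothing on hand accounts for the lower read-out of compound 3.

Open, as far as these compounds go, is whether an amine, a carboxylic acid or a longer alkyl chain on this nitrogen would lift the read-out above that of compound 1, or whether the read-out stays low across such groups. The shared core is the same in all three compounds, so these results say nothing about changes elsewhere in it.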